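Swapping the furan for a methylthiophene on compound 1

A few compounds are considered here, and "the series" means these few. Any claim that something is new, unique, unknown or untested is made for them only; others in the source may bear on it.

Measured so far:
compound 1, `O=C(CCCCCCC(=O)Nc1nnc(-c2ccco2)s1)NO` — 880 nM
compound 2, `Cc1ccc2c(c1)/C(=N\O)C(=O)N2CCCC(=O)NO` — 490 nM

Among the compounds with values here, the two measured compounds share a hydroxamic acid but otherwise differ in many places, so no single step between them can be named. In a functional assay on SW-620 cells (Homo sapiens) for inhibition, read by MTT assay (on this read-out lower numbers stand for stronger inhibition and higher numbers for weaker inhibition), compound 1 gives 880 nM, the higher of the two numbers; compound 2 gives 490 nM, and the gap between the two stays within the usual scatter, so neither can be called the more potent.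

Compound 3, `Cc1ccc(-c2nnc(NC(=O)CCCCCCC(=O)NO)s2)s1`, has not yet been tested in this assay. It differs from compound 1 in one place: 5-methylthiophen-2-yl in place of furan-2-yl on an aromatic carbon. The change sits on an aromatic carbon of a five-membered aromatic ring with 2 nitrogen and 1 sulfur, two ring bonds from the ring atom that bears a large group, far from the hydroxamic acid. Within the data shown here, nothing among the measured compounds shows what such a swap does here.

Compound 3 is therefore expected to land close to compound 1, with the step of a 1.3-fold lower number from compound 1 to compound 3 (0.10 log units; within the scatter) not beyond the scatter; the estimate for compound 3 in this assay is 700 nM, within 250 nM to 2000 nM.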

Compound 3, half-maximal inhibitory concentration: 880 nM
Compound 3: the middle estimate sits 1.3-fold (0.10 log units) below what was measured; the range from low to high includes it.
By their numbers in this assay, from the lowest: compounds 2, 1 and 3 (each within the scatter of the next).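

In this assay, within the data shown here, placing 5-methylthiophen-2-yl where furan-2-yl stood gives no change at the digits printed from compound 1 to compound 3 (within the scatter), the first direct reading of a change at this position, on an aromatic carbon of the five-membered aromatic ring with 2 nitrogen and 1 sulfur. The swap replaces a ring holding oxygen and 5 heavy atoms with a ring holding sulfur and 6 heavy atoms, and this assay does not separate the two compounds, so for this one pair neither the ring hetero atom nor the added methyl comes with a step beyond the scatter. No measurement shown here offers an explanation for this result.

The exchange of oxygen for sulfur and the addition of the methyl arrive together, so the compounds shown cannot say what each does alone, or whether the two offset each other; thiophen-2-yl without its methyl would be needed to tell them apart. As far as these compounds go, it also remains open whether the position would respond the same way to a group of another kind, such as a phenyl ring, a primary amine or a carboxylic acid.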